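A few compounds are considered here, and "the series" means these few. Any claim that something is new, unique, unknown or untested is made for them only; others in the source may bear on it.

Compound 1 `Nc1cccc(-c2cn3nc(-c4ccc(F)cc4)sc3n2)c1`; compound 2 `C=C(Br)C(=O)Nc1cccc(-c2cn3nc(Cc4ccc(OC)cc4)sc3n2)c1`; compound 3 `C=C(Br)C(=O)Nc1cccc(-c2cn3nc(Cc4ccccc4)sc3n2)c1`.

In a functional assay on HeLa cells (Homo sapiens) for inhibition, read by cell counting, with a stated time of 4 days (on this read-out higher numbers stand for weaker inhibition and lower numbers for stronger inhibition), compound 1 gives >= 250000 nM, which is a limit of the assay and not a measured number. In this assay compound 2 gives 2300 nM, and compound 3 gives 4500 nM. Compound 1 thus stands apart from the other two, sitting at the limit of >= 250000 nM in this assay, at which 1 of the 3 values shown sits.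

Compound 4 `Cc1ccc(-c2nn3cc(-c4cccc(N)c4)nc3s2)cc1` differs from compound 1 by methyl in place of fluoro on an aromatic carbon. Going by the values given here, only one measured step is available, a 2.0-fold higher number from compound 2 to compound 3 (0.29 log units; within the scatter), and it changes a different part of the molecule from the one altered here, in compounds that also differ from compound 1 in other places. It shows that a small change on an outer aromatic ring moved the result by an amount within the scatter. Nothing in the measured compounds suggests that swapping one small substituent for another on the outer ring would lift compound 1 off its limit. Compound 4 is therefore expected to remain at the limit, with a number no higher from compound 1 to compound 4 (the limit leaves the size open). Compound 4 is estimated at 250000 nM, within 100000 nM to 600000 nM.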

Compound 4, half-maximal inhibitory concentration: 8900 nM
Compound 4: middle estimate off by 28-fold (1.45 log units), on the high side; measured number outside the range, below it.
By their numbers in this assay, from the lowest: compounds 2, 3 and 4 (each within the scatter of the next, the first and the last beyond it). At a limit, above all of these: compound 1.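

At this position, para to a large group, the change from 4-fluorophenyl to 4-methylphenyl proves far from silent in this assay: the step reads an at least 28-fold lower number from compound 1 to compound 4 (1.44 log units; beyond the scatter). The earlier step on an outer ring stayed within the scatter, whereas this exchange of one heavy atom for another, with no hydrogen-bond donor or acceptor entering or leaving, lifts the series off its limit. The true size of the step stays open because compound 1 has no measured number, only a limit: the limit of >= 250000 nM in this assay, at which 1 of the 4 values shown sits.

The compounds shown leave open how a chloro or a trifluoromethyl group would read on this same aromatic carbon. They also leave open whether methyl in place of fluoro would act in the same way in compounds built like compound 2 and compound 3.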